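Branching the Alkylamino Chain: Expected Cytotoxicity of Compound 3

The source may hold more compounds than are shown below. What is called first, only, known or untested is meant among the compounds shown, and "the series" means these compounds.

Compound 1, `CCCNc1nc(N)nc2c1ncn2/C=C1/CC1(CO)CO`: > 300000 nM
Compound 2, `CCCCNc1nc(N)nc2c1ncn2/C=C1/CC1(CO)CO`: > 300000 nM

In an ADME assay on HFF cells (Homo sapiens) for cytotoxicity, with a stated time of 8 days (on this read-out lower numbers stand for higher toxicity in this test and higher numbers for lower toxicity in this test), compound 1 reaches only the limit of the test, > 300000 nM, so no number is known for it. Compound 2 likewise sits at a limit in this assay, > 300000 nM. Among the compounds with values here, the step that the two limits leave unreadable from compound 1 to compound 2 is therefore not readable in size or direction; it is the only measured step, and it bears on the present question only by showing that lengthening the chain on the ring nitrogen left both compounds at the same limit.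

Compound 3, `CC(C)Nc1nc(N)nc2c1ncn2/C=C1/CC1(CO)CO`, differs from compound 1 by isopropyl in place of propyl on a nitrogen on an aromatic ring. Because (the limit of > 300000 nM in this assay, at which 2 of the 2 values shown sit), compound 3 is expected to stay at that limit as well, and the estimated step that the limit leaves unreadable from compound 1 to compound 3 is expected to be none beyond the scatter. The estimate for compound 3 in this assay is 400000 nM, with a range from 150000 nM to 1500000 nM, most likely reported only as a limit.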

Compound 3, half-maximal cytotoxic concentration: > 300000 nM
Compound 3 ended at the assay's limit; the forecaster's own chance of this, stated with the estimate: 85%; the middle value does not contradict the limit.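

In this assay, no step can be read between compound 1, compound 2 and compound 3 because each result is only a limit: the limit of > 300000 nM in this assay, at which 3 of the 3 values shown sit.

The compounds shown leave open whether propyl, butyl and isopropyl on a nitrogen on an aromatic ring differ at all in half-maximal cytotoxic concentration.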